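The source may hold more compounds than are shown below. What is called first, only, known or untested is meant among the compounds shown, and "the series" means these compounds.

In a functional assay on COLO 205 cells (Homo sapiens) for cytotoxicity (on this read-out higher numbers stand for weaker inhibition and lower numbers for stronger inhibition), compound 1 (`Cc1ccc(S(=O)(=O)N/C(=N\O)Nc2ccc(Cl)cc2)cc1`) gives 58 ug/mL and lies within the scatter of both other measured compounds. For the measured compounds named here, with compound 2 (`O=S(=O)(N/C(=N\O)Nc1ccc(Cl)cc1)c1ccc(-c2cccs2)cn1`) at 74 ug/mL and compound 3 (`O=S(=O)(N/C(=N\O)Nc1ccc(Cl)cc1)c1cc(-c2ccsc2)no1`) at 52 ug/mL for comparison, compound 1 stands level with them, and no measured compound separates from it.

Compound 4 (`CCCCOc1ccc(S(=O)(=O)N/C(=N\O)Nc2ccc(Cl)cc2)cc1`) keeps the core of compound 1 with one change (butoxy in place of methyl on an aromatic carbon): butoxy in place of methyl on an aromatic carbon, para to a large group. Going by the values given here, no measured pair isolates a change of this kind, so no direct step is available. Compound 2 at 74 ug/mL and compound 3 at 52 ug/mL do carry other groups at that end of the molecule and still stay within the scatter of compound 1. In this assay no step beyond the scatter is therefore expected, at most a slight drift toward stronger inhibition. The step expected is a 1.3-fold lower number from compound 1 to compound 4 (0.11 log units; within the scatter) and it would stay within the scatter. The estimate for compound 4 is 45 ug/mL (expected range 20 ug/mL to 90 ug/mL).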

Compound 4, half-maximal inhibitory concentration: 49 ug/mL
Beside the measured number, compound 4's estimate is 1.1-fold (0.04 log units) below it; measured number inside the range.
By their numbers in this assay, from the lowest: compounds 4, 3, 1 and 2 (each within the scatter of the next).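

In this assay, for the compounds shown here, the pair gives the one direct reading of a change at this place, on an aromatic carbon of a six-membered aromatic ring of carbon only, para to a large group: butoxy in place of methyl is a 1.2-fold lower number from compound 1 to compound 4 (0.07 log units; within the scatter). The position therefore takes a group of 5 heavy atoms, one of them an oxygen that counts as a hydrogen-bond acceptor, in place of a single carbon without a step beyond the scatter. Nothing given here bears on why the number holds level.

As far as these compounds go, whether an amine, a carboxylic acid or a chain longer than butoxy at this carbon would stay within the scatter remains open. The compounds shown also leave open whether butoxy would give the same result on another core.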